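Chloro Swap Carried onto the Nitrile Analogue

The compounds below may be only part of what the source reports. "The series", "measured", "known", "first", "only" and "open" are said of these compounds alone.

Three compounds sharing one core were tested in a functional assay on MT4 cells (Homo sapiens) for antiproliferative activity, read by MTT assay, with a stated time of 96 h; on this read-out higher numbers stand for an effect only at larger amounts of compound and lower numbers for an effect already at smaller amounts. Compound 3 `CCOC(=O)/C(=C/c1c(-c2ccccc2)[nH]c2ccccc12)C(=O)c1ccccc1` gives 7000 nM, compound 1 `CCOC(=O)/C(=C/c1c(-c2ccccc2)[nH]c2ccccc12)C(=O)c1ccc(Cl)cc1` gives 9000 nM, and compound 2 `N#C/C(=C\c1c(-c2ccccc2)[nH]c2ccccc12)C(=O)c1ccccc1` gives 500 nM. From compound 3 to compound 1 the change is chloro in place of hydrogen on an aromatic carbon, and this gave a 1.3-fold higher number from compound 3 to compound 1 (0.11 log units; within the scatter). How compound 2 differs from compound 3 is not broken down here; the two values show that compound 2 stands well apart from compound 3 and compound 1 in this assay. Compound 4 `N#C/C(=C\c1c(-c2ccccc2)[nH]c2ccccc12)C(=O)c1ccc(Cl)cc1` is not yet measured; from compound 2 it differs by chloro in place of hydrogen on an aromatic carbon, the same change as from compound 3 to compound 1. In this assay the step is expected to be a 1.2-fold higher number from compound 2 to compound 4 (0.08 log units; within the scatter) because the earlier change gave a 1.3-fold higher number from compound 3 to compound 1 (0.11 log units; within the scatter). Compound 4 is therefore estimated at 600 nM, likely between 250 nM and 1500 nM.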

Compound 4, half-maximal effective concentration: 400 nM
The estimate for compound 4 lay 1.5-fold (0.18 log units) above the measured number, within the range that was stated.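

In this assay, going from benzoyl to (4-chlorophenyl)carbonyl on the core of compound 2 gave a 1.3-fold lower number from compound 2 to compound 4 (0.10 log units; within the scatter), so the swap leaves no readable mark on this core. The core of compound 3 shows the same, and the two steps agree: the same change on two cores in this assay, a 1.3-fold higher number (0.11 log units; within the scatter) from compound 3 to compound 1 and a 1.3-fold lower number (0.10 log units; within the scatter) from compound 2 to compound 4, 1.6-fold (0.21 log units) apart, within the scatter of two such steps

For the compounds shown here, this supports carrying the change across these two cores as a step too small to read, but it rests on only two pairs and one position, so it gives no rule for other cores or other groups. The compounds shown leave open whether a methoxy group, an amine or a carboxylic acid in that same place would shift the number on either core. They also leave open whether the two cores would respond alike to such a group.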